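A Methoxy Swap on the Shared Core

The compounds below may be only part of what the source reports. "The series", "measured", "known", "first", "only" and "open" are said of these compounds alone.

Compound 1 `COc1cc(-c2ccnc3cc(-c4ccc(Cl)cc4)nn23)cc(OC)c1OC` gives 2320 nM in this series
Compound 2 `COc1cc(-c2ccnc3cc(-c4cccc(C)c4)nn23)cc(OC)c1OC` gives 1080 nM in this series
Compound 3 `COc1ccc(-c2cc3nccc(-c4cc(OC)c(OC)c(OC)c4)n3n2)cc1` has not yet been measured

Within the data shown here, in a functional assay on MCF7 cells (Homo sapiens) for inhibition, read by CCK-8 assay, with a stated time of 48 h (a higher number here means a weaker inhibitor, a lower number a stronger inhibitor), compound 2 holds the lower of the two numbers so far (1080 nM), and compound 1 is its only neighbour. The move to compound 3 (4-methoxyphenyl in place of 3-methylphenyl on an aromatic carbon) puts 4-methoxyphenyl in place of 3-methylphenyl on an aromatic carbon of a five-membered aromatic ring with 2 nitrogen. Among the measured compounds shown here, one measured step bears on this change (a 2.1-fold lower number from compound 1 to compound 2 (0.33 log units; beyond the scatter)). It was modest, and it replaced 4-chlorophenyl with 3-methylphenyl at the same place. Compound 3 carries a 4-methoxyphenyl, closer in name to the 4-chlorophenyl of compound 1 (2320 nM) than to the group it replaces. A single pair sets no rule, so only a slight move toward the higher number is expected. The expected step is small (a 1.4-fold higher number from compound 2 to compound 3 (0.14 log units; within the scatter)), and its direction is uncertain. The estimated value for compound 3 is 1500 nM within a range of 550 nM to 4000 nM in this assay once it is measured.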

Compound 3, half-maximal inhibitory concentration: 125 nM
For compound 3 the middle estimate is 12-fold (1.08 log units) above the measured one; measured number below the stated range.
By their numbers in this assay, from the lowest: compound 3; then compound 2; then compound 1.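

This position proved far more sensitive than the first pair suggested. In this assay, 4-methoxyphenyl in place of 3-methylphenyl gave a much larger change (an 8.6-fold lower number from compound 2 to compound 3 (0.94 log units; beyond the scatter)), and methoxy in place of chloro on the same phenyl carbon gave the largest step of the series (a 19-fold lower number from compound 1 to compound 3 (1.27 log units; beyond the scatter)). Compound 1 and compound 3 differ only in that one group on the phenyl ring, so the group's identity at that carbon can shift the number strongly, and the shared 4-substitution of the two compounds does not by itself set the result; nothing measured here gives a reason for the step.

The step from compound 2 to compound 3 changes both the group and its place on the phenyl ring, so these compounds cannot separate those two contributions, and a 3-methoxyphenyl would be the direct test. From the compounds shown here alone, it also remains open whether the low number is particular to methoxy or extends to a 4-ethoxyphenyl, a 4-hydroxyphenyl or a 4-aminophenyl at the same aromatic carbon.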